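Working notes: from compound 2 to compound 4

A few compounds are considered here, and "the series" means these few. Any claim that something is new, unique, unknown or untested is made for them only; others in the source may bear on it.

compound 1 `C[C@H](Oc1ccc2ncc(/C=C/S(=O)(=O)O)c(C3CC3)c2c1)c1c(Cl)ccc(F)c1Cl` gives 2.5
compound 2 `C[C@H](Oc1ccc2ncc(/C=C/c3nn[nH]n3)c(C3CC3)c2c1)c1c(Cl)ccc(F)c1Cl` gives 3.7
compound 3 `C[C@H](Oc1ccc2ncc(/C=C/c3nn[nH]n3)c(C3CC3)c2c1)c1c(Cl)cccc1Cl` gives 4.3

In a physicochemical assay for lipophilicity, using the shake flask method (a higher number here means a more lipophilic compound, a lower number a more polar compound), compound 2 gives 3.7 and stands second highest of the three measured compounds. Compound 4 `C[C@H](Oc1ccc2ncc(S(=O)(=O)CC(=O)O)c(C3CC3)c2c1)c1c(Cl)ccc(F)c1Cl` differs from it as follows: (carboxymethyl)sulfonyl in place of 2-(2H-tetrazol-5-yl)ethenyl on an aromatic carbon with (carboxymethyl)sulfonyl in place of 2-(2H-tetrazol-5-yl)ethenyl on an aromatic carbon. The step that bears most closely is a number 1.20 log units higher from compound 1 to compound 2 (beyond the scatter) and it is large, since it exchanges sulfo for the tetrazolyl group. The other step, a number 0.60 log units higher from compound 2 to compound 3 (beyond the scatter) is modest and leaves that chain untouched. Compound 1 at 2.5 suggests a large drop in this assay on leaving the tetrazolyl group. Expected here is a number 1.10 log units lower from compound 2 to compound 4 (beyond the scatter) as a large downward step. Estimated for compound 4 is 2.6 with a range from 1.9 to 3.3 as the expected span.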

Compound 4, distribution coefficient: 2.5
The estimate for compound 4 lay 0.10 log units above the measured number; measured number inside the range.
By their numbers in this assay, from the lowest: compounds 1 and 4 (each within the scatter of the next); then compound 2; then compound 3.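

In this assay, the aromatic carbon ortho to a cyclopropyl group now carries (carboxymethyl)sulfonyl, a group with no ring, and the change from 2-(2H-tetrazol-5-yl)ethenyl gives a number 1.20 log units lower from compound 2 to compound 4 (beyond the scatter). The two ring-free groups bearing sulfur, one with a carboxylic acid and one with sulfo on a chain, cannot be told apart here: no change at the digits printed from compound 1 to compound 4 (within the scatter). The data offer no explanation for either result. From the compounds shown here alone, a methylsulfonyl group or a longer chain ending in an amide at this carbon remains open, so it is unclear how far this level extends to other ring-free groups.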